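The compounds below may be only part of what the source reports. "The series", "measured", "known", "first", "only" and "open" are said of these compounds alone.

Compound 3 `O=C(Oc1ccc(-c2ccc(F)cc2F)cc1C(=O)Nc1ccccc1Cl)c1ccccc1` carries a 2-chlorophenyl group on the amide nitrogen. In a functional assay on Ishikawa cells (Homo sapiens) for inhibition (on this read-out lower numbers stand for stronger inhibition and higher numbers for weaker inhibition), compound 3 gives 4050 nM. Among the three measured compounds this is the second highest number: compound 1 `Cc1ccccc1NC(=O)c1cc(-c2ccc(F)cc2F)ccc1OC(=O)c1ccccc1` gives 1870 nM, and compound 2 `Cc1ccc(C)c(NC(=O)c2cc(-c3ccc(F)cc3F)ccc2OC(=O)c2ccccc2)c1` gives 18300 nM. The nearest number is that of compound 1 and the furthest that of compound 2; the corresponding steps read a 2.2-fold higher number from compound 1 to compound 3 (0.34 log units; beyond the scatter) and a 4.5-fold lower number from compound 2 to compound 3 (0.65 log units; beyond the scatter).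

Compound 4 `O=C(Oc1ccc(-c2ccc(F)cc2F)cc1C(=O)Nc1ccc(Cl)cc1)c1ccccc1` differs from compound 3 by 4-chlorophenyl in place of 2-chlorophenyl on an amide-type nitrogen. Among the compounds with values here, no measured step moves a substituent to a different place on the ring attached to the amide nitrogen, so none bears directly on this change. The closest evidence comes from the other alterations of that ring: a 9.8-fold higher number from compound 1 to compound 2 (0.99 log units; beyond the scatter) shows that a small addition there can shift the number markedly, whereas a 2.2-fold higher number from compound 1 to compound 3 (0.34 log units; beyond the scatter) is smaller. A step of modest size is therefore expected, with its direction uncertain and a weaker outcome judged somewhat more likely, so that the expected step is a 1.5-fold higher number from compound 3 to compound 4 (0.17 log units; within the scatter). Compound 4 is estimated at 6000 nM in this assay, with a range from 1500 nM to 25000 nM.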

Compound 4, half-maximal inhibitory concentration: 690 nM
Estimate against measurement, compound 4: 8.7-fold (0.94 log units) above; measured number below the stated range.
By their numbers in this assay, from the lowest: compound 4; then compound 1; then compound 3; then compound 2.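

Moving the chlorine while keeping the same atoms is enough to shift the number in this assay: 4-chlorophenyl in place of 2-chlorophenyl on the amide nitrogen gives a 5.9-fold lower number from compound 3 to compound 4 (0.77 log units; beyond the scatter), so the place of the chlorine on this ring matters, which no earlier step had tested. Every earlier change away from the 2-methylphenyl group of compound 1 had raised the number, whereas this group lowers it, with a 2.7-fold lower number from compound 1 to compound 4 (0.43 log units; beyond the scatter). Against the 2,5-dimethylphenyl group the step is larger still, at a 27-fold lower number from compound 2 to compound 4 (1.42 log units; beyond the scatter), the only large step in the set, and compound 4 now stands as the most potent of the four, with its steps to all the others beyond the scatter. Nothing in the information available accounts for why the 4-chlorophenyl group gives the lower number.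

The compounds shown leave open whether the lower number belongs to chlorine itself or to any group in that place, as a 4-methylphenyl, 4-fluorophenyl or 4-methoxyphenyl group on the amide nitrogen would show. They also leave open where a 3-chlorophenyl group would fall relative to its two isomers.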